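Purine series: aryl amine exchange on the core

The source may hold more compounds than are shown below. What is called first, only, known or untested is meant among the compounds shown, and "the series" means these compounds.

Measured compounds so far in a functional assay on BT-474 cells (Homo sapiens) for inhibition, read by fluorescence, with a stated time of 72 h; on this read-out lower numbers stand for stronger inhibition of growth and higher numbers for weaker inhibition of growth:
- compound 1, `CC(C)CCn1cnc2c(Nc3ccc(Cl)cc3)nc(N[C@H]3CC[C@H](N)CC3)nc21`, gives 5100 nM
- compound 2, `N[C@H]1CC[C@H](Nc2nc(Nc3ccc(Cl)cc3)c3ncn(C4CCCCC4)c3n2)CC1`, gives 4100 nM

Compound 1 stands at the highest of the two numbers; its nearest neighbour is compound 2, reached by a 1.2-fold lower number from compound 1 to compound 2 (0.09 log units; within the scatter), so the two are indistinguishable on this read-out. Compound 3, `COc1cc(Nc2nc(N[C@H]3CC[C@H](N)CC3)nc3c2ncn3CCC(C)C)cc(OC)c1`, is not yet measured. It differs from compound 1 by 3,5-dimethoxyphenyl in place of 4-chlorophenyl on a nitrogen on an aromatic ring. For the measured compounds named here, the only measured step concerns the group on the aromatic nitrogen, not this position, so no step bears directly on the change. Compound 3 is therefore expected near compound 1, with a wide range: a 1.0-fold lower number from compound 1 to compound 3 (0.01 log units; within the scatter). The estimate for compound 3 is 5000 nM, between 1500 nM and 16000 nM.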

Compound 3, concentration for 50% growth inhibition: 5900 nM
Beside the measured number, compound 3's estimate is 1.2-fold (0.07 log units) below it; measured number inside the range.
By their numbers in this assay, from the lowest: compounds 2, 1 and 3 (each within the scatter of the next).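

In this assay, this position on the nitrogen on an aromatic ring now has its first reading: 3,5-dimethoxyphenyl in place of 4-chlorophenyl gives a 1.2-fold higher number from compound 1 to compound 3 (0.06 log units; within the scatter). The two aryl groups therefore cannot be told apart here, although they differ in size and in their substituents. Nothing available accounts for this result.

Open, as far as these compounds go, is whether a pyridyl ring or a benzyl group on this nitrogen would give a step beyond the scatter. Also open, from the compounds shown here alone, is whether 3,5-dimethoxyphenyl reads the same when combined with the cyclohexyl group of compound 2.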